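Tolerance of a Sulfonamide Series in Kidney Cells

The compounds below may be only part of what the source reports. "The series", "measured", "known", "first", "only" and "open" are said of these compounds alone.

Compound 1 `N#CCCN(Cc1cccs1)S(=O)(=O)c1ccccc1F` is tested in an ADME assay on MDCK cells (Canis lupus familiaris) for cytotoxicity, read by MTT assay, with a stated time of 24 h; a higher number here means that more compound is tolerated, a lower number that less compound is tolerated. In this assay compound 1 reaches only a limit, > 205000 nM, and not a number. Compound 2 `N#CCCN(Cc1cccs1)S(=O)(=O)c1ccc(F)cc1` likewise gives a limit of > 205000 nM. Compound 3 `N#CCCN(Cc1cccs1)S(=O)(=O)c1ccc(Cl)cc1` also stops at a limit, > 195000 nM. The measured steps a step that the two limits leave unreadable from compound 1 to compound 2, a step that the two limits leave unreadable from compound 1 to compound 3 and a step that the two limits leave unreadable from compound 2 to compound 3 cannot be sized because the limit of > 205000 nM in this assay, at which 2 of the 3 values shown sit, and the limit of > 195000 nM in this assay, at which 1 of the 3 values shown sits, cap every value. Compound 4 `N#CCCN(Cc1cccs1)S(=O)(=O)c1ccc(N)cc1` differs from compound 1 by 4-aminophenyl in place of 2-fluorophenyl on a sulfonyl sulfur. With all three neighbours at their limits, compound 4 is expected to sit at the limit too, its estimated value 205000 nM lying between 100000 nM and 400000 nM, an expected step of a number no higher from compound 1 to compound 4 (the limit leaves the size open).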

Compound 4, half-maximal cytotoxic concentration: > 207000 nM
Compound 4: only a limit was reported; the forecaster's own chance of this, stated with the estimate: 85%; middle value at least 1.0-fold (0.00 log units) from the limit.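

In this assay, going by these compounds alone, compound 4, like compound 1, compound 2 and compound 3, gives only a limit, and no step between compound 4 and these three can be read. The compounds shown leave open where any true cytotoxic concentration lies, and whether the group on the sulfonyl sulfur changes it.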